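The source may report more compounds than this note shows. Statements on the series, on what has been measured and on what is new or still open speak of the compounds shown alone.

Compound 1, `CCOc1ncc(-c2nc(C(F)(F)F)sc2N2CCN(C(=O)Cn3cnc4ccccc43)[C@H](C)C2)cn1`: 192 nM
Compound 2, `CCOc1ncc(-c2nc(C(F)(F)F)sc2N2CCN(C(=O)Cn3c(=O)oc4ccccc43)[C@H](C)C2)cn1`: 536 nM
Compound 3, `CCOc1ncc(-c2nc(C(F)(F)F)sc2N2CCN(C(=O)Cn3nc(C)nc3C)[C@H](C)C2)cn1`: 364 nM

In an assay on blood for inhibition of C-X-C chemokine receptor type 3 (Homo sapiens), with a stated time of 30 min (a lower number here means a stronger inhibitor, a higher number a weaker inhibitor), compound 3 stands second highest of the three numbers; the step of a 1.5-fold lower number from compound 2 to compound 3 (0.17 log units; within the scatter) and the step of a 1.9-fold higher number from compound 1 to compound 3 (0.28 log units; within the scatter) both lie within the scatter. Compound 4, `CCOc1ncc(-c2nc(C(F)(F)F)sc2N2CCN(C(=O)Cn3cc(Cl)cn3)[C@H](C)C2)cn1`, differs from compound 3 by 4-chloro-1H-pyrazol-1-yl in place of 3,5-dimethyl-1H-1,2,4-triazol-1-yl on a saturated chain carbon bound to a carbonyl carbon. Among the measured compounds shown here, the steps that bear on this position are a 1.9-fold higher number from compound 1 to compound 3 (0.28 log units; within the scatter) and a 1.5-fold lower number from compound 2 to compound 3 (0.17 log units; within the scatter), both within the scatter, while a 2.8-fold higher number from compound 1 to compound 2 (0.45 log units; beyond the scatter) is the only change at this position beyond it, and only modestly so. An exchange of one five-membered aromatic ring for another at this position is therefore expected to give no step beyond the scatter in this assay, in either direction. Compound 4 is estimated at 350 nM, with a range of 150 nM to 900 nM, which means an expected step of a 1.0-fold lower number from compound 3 to compound 4 (0.02 log units; within the scatter).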

Compound 4, half-maximal inhibitory concentration: 245 nM
Beside the measured number, compound 4's estimate is 1.4-fold (0.15 log units) above it, within the range that was stated.
By their numbers in this assay, from the lowest: compounds 1, 4, 3 and 2 (each within the scatter of the next, the first and the last beyond it).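

In this assay, a single five-membered aromatic ring, 4-chloro-1H-pyrazol-1-yl, gives a 1.3-fold higher number from compound 1 to compound 4 (0.11 log units; within the scatter) and so matches 1H-benzimidazol-1-yl within the scatter, while a 1.5-fold lower number from compound 3 to compound 4 (0.17 log units; within the scatter) also leaves it level with 3,5-dimethyl-1H-1,2,4-triazol-1-yl. It further gives a 2.2-fold lower number from compound 2 to compound 4 (0.34 log units; beyond the scatter) as a second modest step beyond the scatter at this position, and compound 2 again lies on the high side. Nothing available explains these steps.

Still open, going by these compounds, is whether the chlorine matters, which 1H-pyrazol-1-yl would test. Also open, on these data alone, is whether an amine or a carboxylic acid on this saturated chain carbon would stay in this range.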